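A few compounds are considered here, and "the series" means these few. Any claim that something is new, unique, unknown or untested is made for them only; others in the source may bear on it.

Measured in a functional assay on HeLa cells (Homo sapiens) for cytotoxicity, read by MTT assay, with a stated time of 2 days; on this read-out lower numbers stand for stronger inhibition and higher numbers for weaker inhibition:

compound 1 `Cc1ccc2nc(-c3ccccc3N(C)C)[nH]c(=O)c2c1`: 14000 nM
compound 2 `Cc1ccc2c(=O)[nH]c(-c3ccccc3F)nc2c1`: 830 nM
compound 3 `Cc1ccc2c(=O)[nH]c(-c3cccc(F)c3)nc2c1`: > 50000 nM (a limit of the assay, not a number)

Compound 1 gives 14000 nM and compound 2 gives 830 nM, so true numbers can be obtained for compounds of this kind. Compound 3 has no number of its own, only a limit, and the record for this set shows (the limit of > 50000 nM in this assay, at which 1 of the 3 values shown sits).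

The compound still to be measured, compound 4 `Cc1ccc2c(=O)[nH]c(-c3cccc(C(F)(F)F)c3)nc2c1`, keeps the shared core of compound 3 and carries trifluoromethyl in place of fluoro on an aromatic carbon.

Among the compounds with values here, no measured pair here differs in just one place, so this assay offers no direct guide to the size of this change, and any forecast must stay loose. The forecast starts from compound 3, whose > 50000 nM is a limit. A small move towards stronger inhibition is expected, or possibly none that can be seen. The expected change is an at least 1.6-fold lower number from compound 3 to compound 4 (0.22 log units; that floor lies within the scatter). Compound 4 is expected to give about 30000 nM, with an estimated range from 7000 nM to 60000 nM. A result reported only as a limit would be no surprise.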

Compound 4, half-maximal inhibitory concentration: > 50000 nM
Compound 4 ended at the assay's limit; the forecaster's own chance of this, stated with the estimate: 45%; middle value at least 1.6-fold (0.22 log units) away from the limit.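

Compound 3 and compound 4 each carry only a limit of the assay, not a number, so the step between them cannot be read: the limit of > 50000 nM in this assay, at which 2 of the 4 values shown sit.

The compounds shown leave open how far either one lies past that limit, and whether trifluoromethyl in place of fluoro on an aromatic carbon changes the read-out at all.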